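This account rests on a few compounds, and the source may have more. Where it says the series, first, only, none or still open, it means among the compounds named here.

The account follows a single change in a small set tested in a functional assay on HeLa cells (Homo sapiens) for inhibition, read by MTT assay, with a stated time of 72 h; a lower number here means a stronger inhibitor, a higher number a weaker inhibitor. Among the measured compounds shown here, compound 1 `COc1cc(OC)c(OC)cc1/C=C/C(=O)c1ccc(C)cc1` gives 42200 nM in this assay, and this is the only value in the set that is a number. Compound 2 `COc1cc(OC)c(OC)cc1/C=C/C(=O)c1cccc(C(F)(F)F)c1` reaches only the limit of > 150000 nM in this assay. Compound 3 `COc1cc(OC)c(-c2cc(=O)c3cc(Cl)ccc3o2)cc1OC` likewise stops at the limit of > 150000 nM in this assay. For the measured compounds named here, two of the three values shown therefore sit at the limit of > 150000 nM in this assay, at which 2 of the 3 values shown sit, and compound 1 stands alone as the one compound with a measured potency.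

Compound 4 `COc1cc(OC)c(OC)cc1/C=C/C(=O)c1ccc(Cl)cc1` has not yet been measured in this assay. It differs from compound 1 in one place: chloro in place of methyl on an aromatic carbon. The new group sits on an aromatic carbon of a six-membered aromatic ring of carbon only, para to a large group, so the whole change reads as 4-methylphenyl to 4-chlorophenyl. No pair of measured compounds differing in a single place is available, so the size of such a step cannot be read from the data shown. Compound 4 is expected to give 30000 nM in this assay, with a likely range from 8000 nM to 120000 nM. The step this estimate means is a 1.4-fold lower number from compound 1 to compound 4 (0.15 log units; within the scatter), expected to stay within the ordinary scatter of repeated measurements.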

Compound 4, half-maximal inhibitory concentration: 36500 nM
For compound 4 the middle estimate is 1.2-fold (0.09 log units) below the measured one; the measured number falls inside the stated range.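

The pair of compound 1 and compound 4 gives the set its first step at a single place, on an aromatic carbon of a six-membered aromatic ring of carbon only, para to a large group: chloro in place of methyl gives a 1.2-fold lower number from compound 1 to compound 4 (0.06 log units; within the scatter). In this assay the two compounds therefore cannot be told apart, so at this position the change from 4-methylphenyl to 4-chlorophenyl leaves the read-out within what repeated measurements would show, and the series now holds a second compound with a measured number rather than a limit. Compound 2 and compound 3 give no such comparison, each of them stopping at a limit of the assay and not at a number: the limit of > 150000 nM in this assay, at which 2 of the 4 values shown sit.

On these data alone, what remains open is whether this position responds to anything other than this one exchange, since a single step within the scatter says nothing about how an amine, a carboxylic acid or a longer chain in the same place would read in this assay. The compounds shown also cannot tell whether the same exchange would give a similar step on another core, and they offer no explanation for the step seen here.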